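This account rests on a few compounds, and the source may have more. Where it says the series, first, only, none or still open, it means among the compounds named here.

Measured compounds:
compound 1 `Nc1nc(Cl)c2ncn(Cc3ccc(CCl)cc3)c2n1`, which in a functional assay on U-251 cells (Homo sapiens) for cytotoxicity, read by sulforhodamine B assay, with a stated time of 48 h (on this read-out higher numbers stand for weaker inhibition of growth and lower numbers for stronger inhibition of growth), gives 3550 nM;
compound 2 `ClCc1cccc(Cn2cnc3c(Cl)nc(Cl)nc32)c1`, which in this assay gives 1690 nM;
compound 3 `ClCc1ccc(Cn2cnc3c(Cl)nc(Cl)nc32)cc1`, which in this assay gives 2040 nM.

Going by the values given here, only one single-point change is seen among the measured compounds. From compound 3 to compound 1 the change is amino in place of chloro on an aromatic carbon, and the number moves a 1.7-fold higher number from compound 3 to compound 1 (0.24 log units; within the scatter). Compound 2 and compound 3 are built from the same atoms joined differently; the difference between the two cores is not broken down here. Compound 2 gives a lower number than compound 1, a gap that lies beyond the scatter, whereas compound 2 and compound 3 lie within the scatter of each other.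

Compound 4 `Nc1nc(Cl)c2ncn(Cc3cccc(CCl)c3)c2n1` has not yet been measured in this assay. It stands to compound 2 as compound 1 stands to compound 3: amino in place of chloro on an aromatic carbon, the same change at the same place. The step from compound 2 to compound 4 is expected to be a 1.7-fold higher number from compound 2 to compound 4 (0.23 log units; within the scatter). Among the compounds with values here, this rests on the single precedent, a 1.7-fold higher number from compound 3 to compound 1 (0.24 log units; within the scatter), a step that itself sits within the scatter. Compound 4 is accordingly estimated at 2900 nM in this assay, within a range from 1400 nM to 6000 nM.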

Compound 4, concentration for 50% growth inhibition: 1820 nM
Compound 4: middle estimate off by 1.6-fold (0.20 log units), on the high side; measured number inside the range.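

On the second core, amino in place of chloro on an aromatic carbon gives a 1.1-fold higher number from compound 2 to compound 4 (0.03 log units; within the scatter) in this assay. Set beside the earlier step, the same change shows no difference between the two cores that exceeds the scatter: the same change on two cores in this assay, a 1.7-fold higher number (0.24 log units; within the scatter) from compound 3 to compound 1 and a 1.1-fold higher number (0.03 log units; within the scatter) from compound 2 to compound 4, 1.6-fold (0.21 log units) apart, within the scatter of two such steps

The change therefore carries across these two cores without any detectable dependence on the core, but this does not show that it shifts growth inhibition, since each step lies within the scatter, and a pair of cores cannot establish a rule for the wider series.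

The compounds shown leave open how a methylamino, hydroxyl or methoxy group would compare with amino and chloro on that same aromatic carbon. They also leave open what follows when the chloromethyl group gives way to a hydroxymethyl group or a longer chain such as chloroethyl, and whether the amino-for-chloro comparison would hold on such compounds.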